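Methyl to 4-methylphenyl on the sulfonyl sulfur

A few compounds are considered here, and "the series" means these few. Any claim that something is new, unique, unknown or untested is made for them only; others in the source may bear on it.

compound 1 `C=C(C(=O)OC)[C@@H]1CC[C@H](C)[C@H]2C(=C(C)C(=O)[C@H]2NC(=O)c2ccccc2)C1` gives 84.3 uM
compound 2 `C=C(C(=O)OC)[C@@H]1CC[C@H](C)[C@H]2C(=C(C)C(=O)[C@H]2NC(=O)C(C)CCl)C1` gives 735 uM
compound 3 `C=C(C(=O)OC)[C@@H]1CC[C@H](C)[C@H]2C(=C(C)C(=O)[C@H]2NS(C)(=O)=O)C1` gives 226 uM

In an ADME assay on MDCK cells (Canis lupus familiaris) for cytotoxicity, with a stated time of 48 h (on this read-out lower numbers stand for higher toxicity in this test and higher numbers for lower toxicity in this test), compound 3 holds the middle place of the three, above compound 1 and below compound 2. Compound 4 (`C=C(C(=O)OC)[C@@H]1CC[C@H](C)[C@H]2C(=C(C)C(=O)[C@H]2NS(=O)(=O)c2ccc(C)cc2)C1`) differs from compound 3 by one change (4-methylphenyl in place of methyl on a sulfonyl sulfur), 4-methylphenyl in place of methyl on a sulfonyl sulfur. Among the compounds with values here, no measured step makes this exchange on a sulfonyl sulfur, so the evidence is indirect. Within the data shown here, compound 1 is the only measured compound with an aromatic ring, and it has the lowest number. Both steps away from it lose that ring and raise the number (an 8.7-fold higher number from compound 1 to compound 2 (0.94 log units; beyond the scatter); a 2.7-fold higher number from compound 1 to compound 3 (0.43 log units; beyond the scatter)). The two ring-free compounds also differ (a 3.3-fold lower number from compound 2 to compound 3 (0.51 log units; beyond the scatter)), so the presence of a ring does not describe the whole spread. Adding a ring is therefore expected to lower the number, by a step similar in size to the one from the benzoyl compound to the methylsulfonyl compound, read in reverse. The expected step for compound 4 is modest and downward (a 2.4-fold lower number from compound 3 to compound 4 (0.38 log units; beyond the scatter)). In this assay the estimated value for compound 4 is 95 uM (range 38 uM to 240 uM).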

Compound 4, half-maximal toxic concentration: 61.1 uM
Compound 4: the middle estimate sits 1.6-fold (0.19 log units) above what was measured; low and high end bracket the measured number.
By their numbers in this assay, from the lowest: compounds 4 and 1 (each within the scatter of the next); then compound 3; then compound 2.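

In this assay, the exchange on the sulfonyl sulfur now has a direct reading: 4-methylphenyl in place of methyl goes with a lower number (a 3.7-fold lower number from compound 3 to compound 4 (0.57 log units; beyond the scatter)), so the link between an aromatic ring and a lower number holds within a sulfonamide pair and no longer rests only on the benzoyl compound. Compound 4 and compound 1 cannot be told apart (a 1.4-fold lower number from compound 1 to compound 4 (0.14 log units; within the scatter)), while compound 2, which has no ring, remains clearly separate (a 12-fold lower number from compound 2 to compound 4 (1.08 log units; beyond the scatter)). No measurement shown here accounts for the change on the sulfonyl sulfur.

On these data alone, whether the lower number follows the ring or the methyl on it stays open, and a plain phenyl or an ethyl on the sulfonyl sulfur would address this. Also open, as far as these compounds go, is whether a chloroalkyl chain on the sulfonyl sulfur would give a number as high as that of compound 2.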